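Moving the Hydroxyl Group on a Hydroxyphenyl Substituent

A few compounds are considered here, and "the series" means these few. Any claim that something is new, unique, unknown or untested is made for them only; others in the source may bear on it.

Measured in a functional assay on DU-145 cells (Homo sapiens) for cytotoxicity, read by CCK-8 assay and cell counting, with a stated time of 2 days; a lower number here means a stronger inhibitor, a higher number a weaker inhibitor:
Compound 1 `Oc1ccc(-c2cc(-c3ccc(Cl)cc3)nc(-c3ccsc3)c2)cc1`: 6940 nM
Compound 2 `Oc1cccc(-c2cc(-c3ccsc3)nc(-c3cccc(Cl)c3)c2)c1`: 3330 nM

Of these two, compound 2 has the lower number in this assay, and its gap to compound 1 lies beyond the usual scatter. Compound 3 `Oc1ccc(-c2cc(-c3ccsc3)nc(-c3cccc(Cl)c3)c2)cc1` has not yet been measured. It differs from compound 2 in one place: 4-hydroxyphenyl in place of 3-hydroxyphenyl on an aromatic carbon. Here 4-hydroxyphenyl takes the place of 3-hydroxyphenyl, on an aromatic carbon opposite the ring nitrogen. For the measured compounds named here, no measured pair isolates this change, so any expectation remains loose. Compound 1 also carries 4-hydroxyphenyl and gives 6940 nM, but its chlorophenyl group is different, so only a modest rise in the number is expected, possibly none beyond the scatter. The expected step is a 1.4-fold higher number from compound 2 to compound 3 (0.13 log units; within the scatter). The estimated value for compound 3 is 4500 nM, with an expected range of 1900 nM to 10500 nM.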

Compound 3, half-maximal inhibitory concentration: 6220 nM
Compound 3: the middle estimate sits 1.4-fold (0.14 log units) below what was measured; the measured number falls inside the stated range.
By their numbers in this assay, from the lowest: compounds 2, 3 and 1 (each within the scatter of the next, the first and the last beyond it).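

In this assay, for the compounds shown here, this is the first pair that isolates the hydroxyl position: with 4-hydroxyphenyl in place of 3-hydroxyphenyl on the aromatic carbon opposite the ring nitrogen, the result is a 1.9-fold higher number from compound 2 to compound 3 (0.27 log units; within the scatter). The same compound also isolates the chlorine position, since 3-chlorophenyl in place of 4-chlorophenyl gives a 1.1-fold lower number from compound 1 to compound 3 (0.05 log units; within the scatter). Neither single change therefore shifts the number beyond the scatter, so these compounds establish no preference between 3-hydroxyphenyl and 4-hydroxyphenyl at this carbon.

No information at hand explains the size of either step. From the compounds shown here alone, it remains open whether 2-hydroxyphenyl, or a phenyl ring carrying a methoxy group, an amine or a carboxylic acid in place of the hydroxyl, would separate from these values at this carbon.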